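Replacing propanoyl with (pyridin-3-yl)carbonyl on the shared core

The compounds below may be only part of what the source reports. "The series", "measured", "known", "first", "only" and "open" are said of these compounds alone.

In an ADME assay on HepG2 cells (Homo sapiens) for cytotoxicity, read by neutral red uptake, with a stated time of 24 h (on this read-out higher numbers stand for weaker inhibition and lower numbers for stronger inhibition), compound 1 `CC(C)C(=O)Oc1c(C(C)C)cc2c3c1OC(=O)[C@@]31CCCC(C)(C)[C@@H]1CC2` gives 112000 nM and compound 2 `CCC(=O)Oc1c(C(C)C)cc2c3c1OC(=O)[C@@]31CCCC(C)(C)[C@@H]1CC2` gives 196000 nM as its value. Compound 2 thus stands level with compound 1, the two numbers lying within the scatter of each other. Compound 3 `CC(C)c1cc2c3c(c1OC(=O)c1cccnc1)OC(=O)[C@@]31CCCC(C)(C)[C@@H]1CC2` keeps the shared core and differs from compound 2 in one place (pyridin-3-yl in place of ethyl on a carbonyl carbon) with pyridin-3-yl in place of ethyl on a carbonyl carbon. Among the measured compounds shown here, the only measured step that bears on this is a shortening of the same acyl chain (a 1.8-fold higher number from compound 1 to compound 2 (0.24 log units; within the scatter)) and it stayed within the scatter. For the measured compounds named here, that step touches a saturated chain only, and no measured compound carries a ring on this carbonyl carbon, so the data give no firm direction for the swap. No step beyond the scatter is therefore expected in this assay although the uncertainty is wide. The estimated change is small (a 1.4-fold lower number from compound 2 to compound 3 (0.15 log units; within the scatter)) and fits that expectation. Compound 3 is expected to give 140000 nM with 55000 nM and 350000 nM as the ends of the estimated range.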

Compound 3, half-maximal inhibitory concentration: 264000 nM
For compound 3 the middle estimate is 1.9-fold (0.28 log units) below the measured one; measured number inside the range.
By their numbers in this assay, from the lowest: compounds 1, 2 and 3 (each within the scatter of the next, the first and the last beyond it).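

In this assay, among the compounds shown here, pyridin-3-yl is the first ring on this carbonyl carbon, and the swap from ethyl gives only a small step (a 1.3-fold higher number from compound 2 to compound 3 (0.13 log units; within the scatter)), so at this level of resolution the ring reads level with the saturated chain. Measured against isopropyl, the same ring gives a modest step that does clear the scatter (a 2.4-fold higher number from compound 1 to compound 3 (0.37 log units; beyond the scatter)), which shows that this position can register a difference in the direction of weaker inhibition, although compound 2 lies within the scatter of both neighbours and the three compounds form a shallow slope rather than two separate levels. Nothing measured here accounts for this small difference between the isopropyl and pyridin-3-yl esters.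

The compounds shown leave open whether a plain phenyl group on this carbonyl carbon would read like pyridin-3-yl, which would separate the contribution of the ring from that of its nitrogen. They also leave open how a longer chain such as hexyl, or a chain ending in an amine or a carboxylic acid, would read at this place.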